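The compounds below may be only part of what the source reports. "The series", "measured", "known", "first", "only" and "open" are said of these compounds alone.

Of the compounds shown here, two built on one shared core have been measured in an assay on cells for inhibition of cytochrome P450 11B2, mitochondrial (Homo sapiens), read by HPLC, with a stated time of 90 min; on this read-out lower numbers stand for stronger inhibition and higher numbers for weaker inhibition. Compound 1 `CN(C)c1ncncc1-c1nc2cc(F)c(F)cc2n1C1CC1` gives 29 nM. Compound 2 `Fc1cc2nc(-c3cncnc3C(F)(F)F)n(C3CC3)c2cc1F` gives 25 nM. Going by the values given here, the single step between them, a 1.2-fold lower number from compound 1 to compound 2 (0.06 log units; within the scatter), is within the scatter, so the two numbers cannot be told apart. Among the compounds with values here, compound 2 thus stands level with compound 1, the only other number available, and no ordering can be drawn from the pair.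

The next compound, compound 3 `CC(F)(F)c1ncncc1-c1nc2cc(F)c(F)cc2n1C1CC1`, differs from compound 2 by methyl in place of fluoro on a saturated chain carbon bound to an aromatic carbon and two fluorine atoms. Read one bond further out, the change is trifluoromethyl to 1,1-difluoroethyl. Within the data shown here, only one measured step touches that place: a 1.2-fold lower number from compound 1 to compound 2 (0.06 log units; within the scatter), a swap that stayed within the scatter. Nothing measured shows a move beyond the scatter at this place, and the present change is a smaller alteration there than the earlier swap. The expected step, no change at the digits printed from compound 2 to compound 3 (within the scatter), is therefore none beyond the scatter. Compound 3 is expected to give 25 nM in this assay, with a range from 12 nM to 55 nM.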

Compound 3, half-maximal inhibitory concentration: 50 nM
Compound 3: middle estimate off by 2.0-fold (0.30 log units), on the low side, and the stated range covers the measured number.
By their numbers in this assay, from the lowest: compounds 2, 1 and 3 (each within the scatter of the next).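

Methyl in place of fluoro on a saturated chain carbon bound to an aromatic carbon and two fluorine atoms gives, in this assay, a 2.0-fold higher number from compound 2 to compound 3 (0.30 log units; within the scatter), so trifluoromethyl to 1,1-difluoroethyl is a further change at this place that does not leave the scatter. The comparison with the dimethylamino group gives a 1.7-fold higher number from compound 1 to compound 3 (0.24 log units; within the scatter), which means that dimethylamino, trifluoromethyl and 1,1-difluoroethyl on this aromatic carbon cannot be told apart on this read-out, and none of the three compounds goes against that reading. No supporting measurement bears on these steps.

Still open, going by these compounds, is whether any group on this aromatic carbon moves the number beyond the scatter, for instance a carboxylic acid, a primary amine, or a longer chain such as n-butyl. The cyclopropyl group and the fluoro groups of the shared core are the same in all three compounds, and what an exchange of those groups would do in this assay remains untested in the compounds shown here.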